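Furoate esters of trimethoxybenzyl alcohol: the aryl substituent

The compounds below may be only part of what the source reports. "The series", "measured", "known", "first", "only" and "open" are said of these compounds alone.

For the measured compounds named here, compound 2 `COc1ccc(-c2ccc(C(=O)OCc3cc(OC)c(OC)c(OC)c3)o2)cc1` carries the higher of the two numbers measured so far in an assay on isolated protein for inhibition of high affinity 3',5'-cyclic-AMP phosphodiesterase 7A (Homo sapiens), read by scintillation proximity assay and cAMP accumulation, with a stated time of 20 min, tested at 10 uM; a lower number here means less inhibition, a higher number more inhibition at the concentration tested (going by the name of the read-out): compound 2 gives 14%. Compound 1 `COc1cc(COC(=O)c2ccc(C)o2)cc(OC)c1OC` differs from compound 2 only at the furan, and there compound 1 gives -9.9%; the change between them reads a number 23.9 percentage points higher from compound 1 to compound 2 (beyond the scatter). Compound 3 `COc1cc(COC(=O)c2ccc(-c3ccc(C)cc3)o2)cc(OC)c1OC` is not yet measured and differs from compound 2 by methyl in place of methoxy on an aromatic carbon. No measured step concerns this position: the single step shown, from compound 1 to compound 2, exchanges methyl for 4-methoxyphenyl on the furan rather than altering a group on the outer phenyl ring, so nothing measured tells how the assay responds to methoxy against methyl at that place. The step for compound 3 is therefore expected to be small, a number 4 percentage points lower from compound 2 to compound 3 (within the scatter), most likely within the scatter in either direction. For compound 3 the estimate in this assay is 10%, with a range from -10% to 30%.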

Compound 3, a percentage reported as inhibition, at one concentration (the size of the read-out at that concentration, not a potency): 30.7%
Estimate against measurement, compound 3: 20.7 percentage points below; the whole stated range lies below it.
By their numbers in this assay, from the lowest: compound 1; then compound 2; then compound 3.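

The outer phenyl ring is not a silent position: in this assay the exchange of methoxy for methyl, para to a large group, reads a number 16.7 percentage points higher from compound 2 to compound 3 (beyond the scatter). The gain from placing an aryl group on the furan therefore depends on what that ring carries, with 4-methylphenyl in place of methyl reading a number 40.6 percentage points higher from compound 1 to compound 3 (beyond the scatter), against a number 23.9 percentage points higher from compound 1 to compound 2 (beyond the scatter) for 4-methoxyphenyl. Nothing measured on these compounds accounts for the difference between methoxy and methyl.

A single pair at this position leaves open whether the trend extends to other groups there, such as an ethyl group, a chlorine atom or an amine, or to a phenyl ring with no such group. These readings at one concentration also leave the potency of compound 3 open.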